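Tolerance limits across the series, from compound 3 to compound 4

A few compounds are considered here, and "the series" means these few. Any claim that something is new, unique, unknown or untested is made for them only; others in the source may bear on it.

Compound 1 `Nc1nc(NCc2ccccc2)c2ncn(/C=C3/CC3(CO)CO)c2n1` sets the core; in an ADME assay on BCBL1 cells (Homo sapiens) for cytotoxicity, with a stated time of 7 days (a lower number here means that less compound is tolerated, a higher number that more compound is tolerated), compound 1 gives 19900 nM. Compound 2 `Nc1nc2c(ncn2/C=C2/CC2(CO)CO)c(=O)[nH]1` reaches only the limit > 20000 nM in this assay. Compound 3 `CCCNc1nc(N)nc2c1ncn2/C=C1/CC1(CO)CO` also reports a limit, > 20000 nM, not a number. Going by the values given here, the single measured step, a number no lower from compound 1 to compound 3 (the limit leaves the size open), has no readable size, and the data carry little spread given (the limit of > 20000 nM in this assay, at which 2 of the 3 values shown sit). Compound 4 `Nc1nc(SCc2ccccc2)c2ncn(/C=C3/CC3(CO)CO)c2n1` differs from compound 3 by benzylsulfanyl in place of propylamino on an aromatic carbon. Among the compounds with values here, no measured step covers this change; a step of an at least 1.1-fold lower number from compound 3 to compound 4 (0.07 log units; that floor lies within the scatter) within the scatter is expected because compound 1, carrying phenyl on the saturated chain carbon bound to a nitrogen on the aromatic ring, gives 19900 nM. Compound 4 is therefore expected to give 17000 nM, ranging between 6000 nM and 20000 nM.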

Compound 4, half-maximal cytotoxic concentration: > 20000 nM
Compound 4 was reported as a limit; the forecaster's own chance of this, stated with the estimate: 50%; middle value at least 1.1-fold (0.07 log units) away from the limit.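

Compound 4 reports only a limit, so benzylsulfanyl on this aromatic carbon gives no number in this assay. A benzyl group carried through sulfur rather than nitrogen does not give a readable value here, and neither step to compound 4 can be read. Most of the series now sits at one ceiling: the limit of > 20000 nM in this assay, at which 3 of the 4 values shown sit.

As far as these compounds go, how far compound 3 and compound 4 lie beyond that limit stays open. In this assay benzylsulfanyl in place of benzylamino on this aromatic carbon gives a number no lower from compound 1 to compound 4 (the limit leaves the size open) and nothing further can be read.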